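The source may report more compounds than this note shows. Statements on the series, on what has been measured and on what is new or still open speak of the compounds shown alone.

Measured so far in a functional assay on HepG2 cells (Homo sapiens) for antiproliferative activity, read by MTT assay, with a stated time of 48 h; on this read-out higher numbers stand for weaker inhibition and lower numbers for stronger inhibition:
- Compound 1 `CCOc1ccc(-c2nc(NS(=O)(=O)c3ccc([N+](=O)[O-])cc3OC)sc2-c2cc(OC)c(OC)c(OC)c2)cc1` gives > 5000 nM as a limit, not a number
- Compound 2 `CCOc1ccc(-c2nc(NS(=O)(=O)c3ccc(OC)c(F)c3)sc2-c2cc(OC)c(OC)c(OC)c2)cc1` gives > 5000 nM as a limit, not a number

Compound 2 therefore has no exact place on the scale. Going by the values given here, it shares its only reported position with compound 1, as the limit of > 5000 nM in this assay, at which 2 of the 2 values shown sit, shows. Among the compounds with values here, the one measured step is a step that the two limits leave unreadable from compound 1 to compound 2 and gives no size to carry forward.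

Compound 3 `CCOc1ccc(-c2nc(NS(=O)(=O)c3ccc(C)c(C)c3)sc2-c2cc(OC)c(OC)c(OC)c2)cc1` keeps the shared core and has 3,4-dimethylphenyl in place of 3-fluoro-4-methoxyphenyl on a sulfonyl sulfur in the same way that compound 2 differs from compound 1 at this place. Two different groups on the sulfonyl sulfur have so far ended at the same limit (the limit of > 5000 nM in this assay, at which 2 of the 2 values shown sit), so a clear gain in this assay is not expected, and no direction can be read from the data. Compound 3 will most likely be reported as a limit again. For compound 3 the estimate is 6000 nM with an expected range from 2000 nM to 15000 nM in this assay. The expected change is a step that the limit leaves unreadable from compound 2 to compound 3 and remains an estimate resting on limits alone.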

Compound 3, half-maximal inhibitory concentration: > 5000 nM
Compound 3: only a limit was reported (the forecaster's own chance of this, stated with the estimate: 70%); the middle value lies beyond the limit too.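

In this assay compound 3 gives > 5000 nM, which is a limit and not a number. The steps connecting compound 1, compound 2 and compound 3 therefore cannot be read: the limit of > 5000 nM in this assay, at which 3 of the 3 values shown sit. The compounds shown leave open how far the three groups on the sulfonyl sulfur differ, and whether any group there would give an exact value.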